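Adding a Methoxy Group to Compound 3

A few compounds are considered here, and "the series" means these few. Any claim that something is new, unique, unknown or untested is made for them only; others in the source may bear on it.

In a functional assay on MCF7 cells (Homo sapiens) for cytotoxicity, read by MTT assay, with a stated time of 48 h (on this read-out lower numbers stand for stronger inhibition and higher numbers for weaker inhibition), the three measured compounds give these numbers:
Compound 1 `COc1ccc(NC(=O)c2cn(-c3ccccc3)nc2-c2ccccc2)cc1` — 1710 nM
Compound 2 `CCOc1ccc(NC(=O)c2cn(-c3ccccc3)nc2-c2ccccc2)cc1` — 880 nM
Compound 3 `Cc1ccc(-c2nn(-c3ccccc3)cc2C(=O)Nc2ccccc2)cc1` — 2450 nM

Compound 3 stands at the highest number of the three; its gap to compound 1 lies within the scatter, its gap to compound 2 beyond it. Compound 4 `COc1ccc(NC(=O)c2cn(-c3ccccc3)nc2-c2ccc(C)cc2)cc1` differs from compound 3 by methoxy in place of hydrogen on an aromatic carbon. Among the measured compounds shown here, no measured step makes this same change. For the measured compounds named here, the only measured step, a 1.9-fold lower number from compound 1 to compound 2 (0.29 log units; within the scatter), alters a different part of the molecule and lies within the scatter. Compound 1 and compound 3, which differ at this place and one other, give numbers within the scatter of each other. The step expected from this change is therefore a 1.4-fold lower number from compound 3 to compound 4 (0.13 log units; within the scatter), with no shift beyond the scatter. Compound 4 is estimated at 1800 nM, with a range from 600 nM to 5400 nM.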

Compound 4, half-maximal inhibitory concentration: 1620 nM
Compound 4: the middle estimate sits 1.1-fold (0.05 log units) above what was measured; the range from low to high includes it.
By their numbers in this assay, from the lowest: compounds 2, 4, 1 and 3 (each within the scatter of the next, the first and the last beyond it).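

In this assay the methoxy on this aromatic carbon gives a 1.5-fold lower number from compound 3 to compound 4 (0.18 log units; within the scatter) and so, at this position in this pair, the change stays inside the scatter. The methyl on an aromatic carbon gives a 1.1-fold lower number from compound 1 to compound 4 (0.02 log units; within the scatter) and so also stays inside the scatter. No evidence on why bears on this result. On these data alone, whether another group at this place, such as an amine or a carboxylic acid, would give a step beyond the scatter remains open.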